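The compounds below may be only part of what the source reports. "The series", "measured", "known", "first", "only" and "open" are said of these compounds alone.

Measured so far:
Compound 1, `CN1CCC[C@H]1[C@@H]1COc2ccc(N)cc2O1`: 46 nM
Compound 2, `CN1CCC[C@H]1[C@H]1COc2c(N)cccc2O1`: 373 nM

Both numbers come from an assay on HeLa cells for displacement of a labelled ligand from Neuronal acetylcholine receptor; alpha4/beta2 (Homo sapiens), with a stated time of 5 min; a lower number here means a stronger inhibitor, a higher number a weaker inhibitor. Compound 1 has the lowest of the two numbers; the nearest is compound 2, whose number is higher by a step that lies beyond the usual scatter, so compound 1 is the stronger binder of the pair. Compound 3, `CN1CCC[C@H]1[C@@H]1COc2ccc(O)cc2O1`, has not yet been measured in this assay. It differs from compound 1 in a single place: hydroxy in place of amino on an aromatic carbon. The group that leaves and the group that enters each bring a single hydrogen-bond donor and acceptor, and the rest of the shared core stays untouched, so no step beyond the scatter is expected in either direction, although a slight weakening would not be surprising. Compound 3 is therefore expected to give about 70 nM in this assay, within a range from 20 nM to 250 nM. The expected step of a 1.5-fold higher number from compound 1 to compound 3 (0.18 log units; within the scatter) is accordingly small.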

Compound 3, inhibition constant: 6.7 nM
The estimate for compound 3 lay 10-fold (1.02 log units) above the measured number; measured number outside the range, below it.
By their numbers in this assay, from the lowest: compound 3; then compound 1; then compound 2.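

In this assay putting hydroxy in place of amino on this aromatic carbon gives a 6.9-fold lower number from compound 1 to compound 3 (0.84 log units; beyond the scatter) and makes compound 3 the stronger binder of this pair. The position therefore distinguishes between two groups that have the same counts of heavy atoms, hydrogen-bond donors and hydrogen-bond acceptors, and those counts alone do not predict the result here. No measurement available here explains the difference between amino and hydroxy.

The compounds shown leave open whether a methoxy group, a fluorine atom or a plain hydrogen on this carbon would bind as well as hydroxy does. They also leave open whether hydroxy in place of amino would give a similar step on another carbon of the same aromatic ring.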